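Side chain notes: compound 3 to compound 4

This account rests on a few compounds, and the source may have more. Where it says the series, first, only, none or still open, it means among the compounds named here.

Measured so far in an ADME assay on Caco-2 cells (Homo sapiens) for permeability, read by LC-MS, in the apical to basolateral direction, with a stated time of 60 min, at pH 6.5 (on this read-out higher numbers stand for higher permeability and lower numbers for lower permeability), for three compounds:
- compound 1 `O=C(NCc1cc(Cl)ccc1-n1cnnn1)[C@@H]1CC=NN1C(=O)[C@H](O)c1ccccc1F` at 8.9 10^-6 cm/s
- compound 2 `CC1(C[C@@H](O)C(=O)N2N=CC[C@H]2C(=O)NCc2cc(Cl)ccc2-n2cnnn2)CC1` at 9.5 10^-6 cm/s
- compound 3 `O=C(NCc1cc(Cl)ccc1-n1cnnn1)[C@@H]1CC=NN1C(=O)[C@H](O)Cc1ccccc1` at 11 10^-6 cm/s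

Compound 3 sits level with the other two: a 1.2-fold higher number from compound 1 to compound 3 (0.09 log units; within the scatter) and a 1.2-fold higher number from compound 2 to compound 3 (0.06 log units; within the scatter) both lie within the scatter. Compound 4 `CC(C)CC[C@@H](O)C(=O)N1N=CC[C@H]1C(=O)NCc1cc(Cl)ccc1-n1cnnn1` has isobutyl in place of phenyl on a saturated chain carbon, two bonds along the chain from a carbonyl carbon and an oxygen on a saturated carbon. Among the measured compounds shown here, three measured steps bear on this. The closest is a 1.2-fold higher number from compound 2 to compound 3 (0.06 log units; within the scatter) with phenyl in place of 1-methylcyclopropyl at that same place. The other two, a 1.1-fold higher number from compound 1 to compound 2 (0.03 log units; within the scatter) and a 1.2-fold higher number from compound 1 to compound 3 (0.09 log units; within the scatter), replace 2-fluorophenyl with (1-methylcyclopropyl)methyl and benzyl. All three stay within the scatter, so no direction is favoured. An estimated 1.1-fold lower number from compound 3 to compound 4 (0.04 log units; within the scatter) in this assay would also stay within the scatter. The estimated value for compound 4 is 10 10^-6 cm/s with an expected range from 5.5 10^-6 cm/s to 18 10^-6 cm/s in this series.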

Compound 4, apparent permeability: 29 10^-6 cm/s
Beside the measured number, compound 4's estimate is 2.9-fold (0.46 log units) below it, and the stated range ends below it.
By their numbers in this assay, from the lowest: compounds 1, 2 and 3 (each within the scatter of the next); then compound 4.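

In this assay, among the compounds shown here, the three earlier side chains at this position could not be told apart, and isobutyl is the first group there to stand clear of the others: the step from phenyl is beyond the scatter (a 2.6-fold higher number from compound 3 to compound 4 (0.42 log units; beyond the scatter)), as is the step from 1-methylcyclopropyl (a 3.1-fold higher number from compound 2 to compound 4 (0.48 log units; beyond the scatter)). Read at the saturated chain carbon bound to a carbonyl carbon and an oxygen, isopentyl in place of 2-fluorophenyl gives a step of similar size (a 3.3-fold higher number from compound 1 to compound 4 (0.51 log units; beyond the scatter)), so the position does respond to the group placed on it. Compound 4 alone carries no ring in this side chain, and nothing measured here explains the higher number.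

A single example cannot separate the absence of a ring from the branching of the chain. An unbranched pentyl chain, a longer chain, or an isopentyl chain ending in an amine or a carboxylic acid would each test how far the step extends.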